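Chain isomers at the limit of the Huh-7 read-out

The source may hold more compounds than are shown below. What is called first, only, known or untested is meant among the compounds shown, and "the series" means these compounds.

Measured in an ADME assay on Huh-7 cells (Homo sapiens) for cytotoxicity, with a stated time of 72 h; a higher number here means that more compound is tolerated, a lower number that less compound is tolerated:
- compound 1 `CC(C)(C)CCn1nc(-c2cccs2)c(O)c(C2=NS(=O)(=O)c3cc(NS(C)(=O)=O)ccc3N2)c1=O`: > 1000 nM (a limit)
- compound 2 `CCC(C)(C)Cn1nc(-c2cccs2)c(O)c(C2=NS(=O)(=O)c3cc(NS(C)(=O)=O)ccc3N2)c1=O`: > 1000 nM (a limit)

Compound 2 gives > 1000 nM, which is a limit of the assay and not a number. Compound 1 gives > 1000 nM, which is likewise a limit. The evidence so far amounts to the limit of > 1000 nM in this assay, at which 2 of the 2 values shown sit.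

The next compound is compound 3 `CCC(C)CCn1nc(-c2cccs2)c(O)c(C2=NS(=O)(=O)c3cc(NS(C)(=O)=O)ccc3N2)c1=O`, which carries 2-methylbutyl in place of 1,1-dimethylpropyl on a saturated chain carbon bound to an aromatic nitrogen.

Within the data shown here, the only measured step bearing on this change is a step that the two limits leave unreadable from compound 1 to compound 2. It gives no size to carry forward, so the expectation rests on compound 2 at > 1000 nM and on the fact that the two chains have the same count under the difference above. No step beyond the scatter is expected in this assay, and no direction is expected either. Another limit is the most likely report. The expected step is a step that the limit leaves unreadable from compound 2 to compound 3. Compound 3 is estimated at 1500 nM, with an expected range of 1000 nM to 5000 nM.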

Compound 3, half-maximal cytotoxic concentration: > 1000 nM
Compound 3 gave a limit, no number; the forecaster's own chance of this, stated with the estimate: 85%; the middle value is on the limit's open side.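

In this assay compound 3 gives > 1000 nM, a limit and not a number. Among these compounds, no step among compound 1, compound 2 and compound 3 can be read: the limit of > 1000 nM in this assay, at which 3 of the 3 values shown sit. The compounds shown leave open where the half-maximal cytotoxic concentration of each compound lies, and whether these chain isomers differ from one another at all.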